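Amide Nitrogen Variation on a Shared Hydroxy-oxo Core

This account rests on a few compounds, and the source may have more. Where it says the series, first, only, none or still open, it means among the compounds named here.

The measured compounds and their values in a functional assay on the whole organism for inhibition, with Rattus norvegicus as the target, read by cytopathic effect and paw edema, at a dose of 100 mg/kg by the oral route; on this read-out higher numbers stand for more inhibition at the one dose given (going by the name of the read-out) and lower numbers for less inhibition:
compound 1 `O=C(NN1CCOCC1)c1c(O)c2cccnc2n(-c2ccccc2)c1=O` gives -26.2%
compound 2 `O=C(Nc1ccc(Cl)cc1)c1c(O)c2cccnc2n(-c2ccccc2)c1=O` gives 2.5%
compound 3 `COc1ccccc1NC(=O)c1c(O)c2cccnc2n(-c2ccccc2)c1=O` gives -10.1%

Compound 3 stands second of the three; compound 2 lies above it by a number 12.6 percentage points lower from compound 2 to compound 3 (beyond the scatter) read in reverse, and compound 1 lies below it by a number 16.1 percentage points higher from compound 1 to compound 3 (beyond the scatter) read in reverse. Compound 4 `O=C(NCc1cccnc1)c1c(O)c2cccnc2n(-c2ccccc2)c1=O` differs from compound 3 only on the amide-type nitrogen: (pyridin-3-yl)methyl in place of 2-methoxyphenyl on an amide-type nitrogen. Among the measured compounds shown here, no measured step swaps an aryl group for an arylmethyl group on that nitrogen, so the nearest guides are the modest changes among the three amide substituents already seen, a number 28.7 percentage points higher from compound 1 to compound 2 (beyond the scatter) and a number 12.6 percentage points lower from compound 2 to compound 3 (beyond the scatter). All three values sit within a narrow band and none shows strong inhibition. Compound 4 is therefore expected to stay in that band, with a step of a number 2.1 percentage points higher from compound 3 to compound 4 (within the scatter) that is not expected to pass beyond the scatter. The estimate for compound 4 in this assay is -8%, ranging from -30% to 15%.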

Compound 4, a percentage reported as inhibition, in the whole organism at one dose (the size of the read-out at that dose, not a potency): 14.7%
Compound 4: the middle estimate sits 22.7 percentage points below what was measured; measured number inside the range.
By their numbers in this assay, from the lowest: compound 1; then compound 3; then compound 2; then compound 4.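

In this assay, among the compounds shown here, the (pyridin-3-yl)methyl group on the amide-type nitrogen gives the highest number of the four, with a number 24.8 percentage points higher from compound 3 to compound 4 (beyond the scatter) and a number 12.2 percentage points higher from compound 2 to compound 4 (beyond the scatter) and also a number 40.9 percentage points higher from compound 1 to compound 4 (beyond the scatter), the only large step seen at this position. The earlier compounds shown here carried either an aryl group or morpholin-4-yl on this nitrogen, and this result shows that a ring held through a methyl link can rise above both, so an aryl group bonded directly to the nitrogen is not required for the higher numbers here. No measurement on hand accounts for this rise.

The change alters both the link and the ring, so the compounds shown do not separate the contribution of the methyl link from that of the ring nitrogen. Benzyl and pyridin-3-yl bonded directly to the amide nitrogen would address that question, and a longer chain carrying the same ring remains open as well.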